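A few compounds are considered here, and "the series" means these few. Any claim that something is new, unique, unknown or untested is made for them only; others in the source may bear on it.

Compound 1 `O=c1ccoc2cc(OCc3cn(Cc4cccc(Br)c4)nn3)ccc12` sits at a limit in a functional assay on SGC-7901 cells (Homo sapiens) for cytotoxicity, read by MTT assay, with a stated time of 48 h; a higher number here means a weaker inhibitor, a lower number a stronger inhibitor: > 100000 nM.
Compound 2 `O=c1ccoc2cc(OCc3cn(Cc4cccc(Cl)c4)nn3)ccc12` sits at a limit: > 100000 nM.
Compound 3 `O=c1ccoc2cc(OCc3cn(Cc4ccccc4F)nn3)ccc12` sits at a limit: > 100000 nM.

Compound 1 stands only at a limit, as do the two others. The step to compound 4 `O=c1ccoc2cc(OCc3cn(Cc4ccccc4Br)nn3)ccc12` is 2-bromophenyl in place of 3-bromophenyl on a saturated chain carbon bound to an aromatic nitrogen. The measured steps that bear on it, a step that the two limits leave unreadable from compound 1 to compound 2, a step that the two limits leave unreadable from compound 1 to compound 3 and a step that the two limits leave unreadable from compound 2 to compound 3, are all unreadable, since every value sits at the limit of > 100000 nM in this assay, at which 3 of the 3 values shown sit. Among the compounds with values here, no step in this assay beyond the scatter is therefore expected, and compound 4 is expected to remain at the limit, a step that the limit leaves unreadable from compound 1 to compound 4. The estimate for compound 4 is 200000 nM, ranging from 50000 nM to 1000000 nM.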

Compound 4, half-maximal inhibitory concentration: > 100000 nM
Compound 4: only a limit was reported; the forecaster's own chance of this, stated with the estimate: 85%; the middle value lies beyond the limit too.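

In this assay, within the data shown here, compound 4 gives > 100000 nM as a limit, so no step between it and compound 1, compound 2 or compound 3 can be read. How these four compounds compare in strength stays open, since all rest at one limit: the limit of > 100000 nM in this assay, at which 4 of the 4 values shown sit.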